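The source may hold more compounds than are shown below. What is called first, only, known or untested is meant among the compounds shown, and "the series" means these compounds.

The measured compounds and their values in a functional assay on A375P cells (Homo sapiens) for antiproliferative activity, read by MTT assay, with a stated time of 48 h; on this read-out lower numbers stand for stronger inhibition and higher numbers for weaker inhibition:

Compound 1 `COc1ccc(C(=O)Nc2cccc(-c3ccnc4c(N)cccc34)c2)cc1OC` — in this assay compound 1 gives 9500 nM.
Compound 2 `Nc1cccc2c(-c3cccc(NC(=O)c4cccc(C(F)(F)F)c4)c3)ccnc12` — in this assay compound 2 gives 7900 nM.
Compound 3 `CC(=O)Nc1cccc2c(-c3cccc(NC(=O)c4cccc(C(F)(F)F)c4)c3)ccnc12` — in this assay compound 3 gives 8000 nM.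

Compound 3 sits among three numbers that all lie within the scatter of one another: the step of a 1.0-fold higher number from compound 2 to compound 3 (0.01 log units; within the scatter) and the gap to compound 1 both fall inside it, so no order among the three can be read from these values.

Compound 4 `CC(=O)Nc1cccc2c(-c3cccc(NC(=O)c4ccc(Cl)cc4C(F)(F)F)c3)ccnc12` differs from compound 3 in one place: 4-chloro-2-(trifluoromethyl)phenyl in place of 3-(trifluoromethyl)phenyl on a carbonyl carbon. The step that bears most directly on this change is the earlier exchange of the aryl group on the same carbonyl carbon, a 1.2-fold lower number from compound 1 to compound 2 (0.08 log units; within the scatter), which stayed within the scatter. The exchange on the ring nitrogen, a 1.0-fold higher number from compound 2 to compound 3 (0.01 log units; within the scatter), also changed nothing beyond the scatter. On this basis the expected step of no change at the digits printed from compound 3 to compound 4 (within the scatter) is none beyond the scatter. Compound 4 is therefore estimated at 8000 nM, with a range from 3000 nM to 20000 nM.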

Compound 4, half-maximal inhibitory concentration: > 20000 nM
Compound 4 was reported as a limit (the forecaster's own chance of this, stated with the estimate: 15%); middle value at least 2.5-fold (0.39 log units) from the limit.
By their numbers in this assay, from the lowest: compounds 2, 3 and 1 (each within the scatter of the next). At a limit, above all of these: compound 4.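

In this assay compound 4 gives > 20000 nM, which is a limit of the assay and not a number: the limit of > 20000 nM in this assay, at which 1 of the 4 values shown sits. Even so, the step of an at least 2.5-fold higher number from compound 3 to compound 4 (0.39 log units; beyond the scatter) is the first among the compounds shown to pass beyond the scatter, whereas the earlier exchange on the same carbonyl carbon, a 1.2-fold lower number from compound 1 to compound 2 (0.08 log units; within the scatter), stayed within it. The aryl group on this carbonyl carbon is therefore not indifferent to the read-out, and for this pair 4-chloro-2-(trifluoromethyl)phenyl goes with weaker inhibition than 3-(trifluoromethyl)phenyl.

The compounds shown leave open whether the step belongs to the chlorine or to the different place of the trifluoromethyl, as 4-chlorophenyl and 2-(trifluoromethyl)phenyl do not appear alone on this carbonyl carbon. Also open, going by these compounds, are how an amine or a carboxylic acid on this aryl ring would read, and whether the exchange behaves alike with hydrogen in place of the acetyl, as in compound 2.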